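A few compounds are considered here, and "the series" means these few. Any claim that something is new, unique, unknown or untested is made for them only; others in the source may bear on it.

Three sulfonamides have so far been run through an assay for inhibition of beta-glucuronidase (Bos taurus), read by spectrophotometry, with a stated time of 30 min; on this read-out lower numbers stand for stronger inhibition and higher numbers for weaker inhibition. Compound 1 `COc1ccc(Br)cc1S(=O)(=O)Nc1cccc2cccnc12` gives 68500 nM, compound 2 `Cc1cc(S(=O)(=O)Nc2cccc3cccnc23)c(C)cc1Cl` gives 24500 nM, and compound 3 `O=[N+]([O-])c1ccccc1S(=O)(=O)Nc1cnc2ccccc2c1` gives 8100 nM, the lowest of the three numbers, with both other compounds standing beyond the scatter above it. Compound 4 `O=S(=O)(Nc1cnc2ccccc2c1)c1ccccc1` has not yet been measured in this assay; it differs from compound 3 by hydrogen in place of nitro on an aromatic carbon. Among the measured compounds shown here, no pair of measured compounds differs by this change alone, so the direction of the step has to be inferred loosely. Among the measured compounds only compound 3 carries a nitro group, and only compound 3 reaches the low end of the range; compound 1 and compound 2, which lack it, sit higher, though both also differ in the shared core and in the other groups on the six-membered aromatic ring, so the comparison is indirect. The expectation is that the step from compound 3 to compound 4 in this assay is a loss beyond the scatter, a 3.1-fold higher number from compound 3 to compound 4 (0.49 log units; beyond the scatter). Compound 4 is accordingly estimated at 25000 nM, with a range from 8000 nM to 80000 nM.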

Compound 4, half-maximal inhibitory concentration: 53400 nM
For compound 4 the middle estimate is 2.1-fold (0.33 log units) below the measured one, within the range that was stated.
By their numbers in this assay, from the lowest: compound 3; then compound 2; then compounds 4 and 1 (each within the scatter of the next).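

Hydrogen in place of nitro on an aromatic carbon, ortho to a large group, gives a 6.6-fold higher number from compound 3 to compound 4 (0.82 log units; beyond the scatter) in this assay, and this is the first reading of the change with nothing else altered. Among the compounds shown here, the nitro group at this place is thus tied directly to the stronger inhibition within this pair, whereas the earlier compounds could link it to the low end of the range only across differing structures. Nothing available bears on what lies behind this step.

From the compounds shown here alone, whether an amine or a carboxylic acid on the same carbon would keep the number of compound 3 or give one nearer that of compound 4 remains open. Going by these compounds, it is also open whether nitro would give a similar step elsewhere on that ring or on the core of compound 1.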